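The compounds below may be only part of what the source reports. "The series", "measured", "known", "first", "only" and "open" are said of these compounds alone.

In a functional assay on 786-0 cells (Homo sapiens) for inhibition, read by sulforhodamine B assay, with a stated time of 48 h (a higher number here means a weaker inhibitor of growth, a lower number a stronger inhibitor of growth), compound 1 (`CC1(/C=C/c2ccccc2)C=CC(=O)O1`) gives 170000 nM and compound 2 (`COc1ccc(/C=C/C2(C)C=CC(=O)O2)c(OC)c1`) gives 108000 nM so that the two stand within the scatter of each other. Compound 3 (`COc1ccc(/C=C/C2(C)C=CC(=O)O2)cc1`) has not yet been measured. Among the measured compounds shown here, it differs from compound 2 by hydrogen in place of methoxy on an aromatic carbon and no measured pair shows this change alone. Compound 2 at 108000 nM therefore remains the reference, and no step beyond the scatter is expected in this assay for this replacement. The value of compound 3 is estimated at 130000 nM with an expected range from 70000 nM to 220000 nM for the coming measurement.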

Compound 3, concentration for total growth inhibition: > 1000000 nM
Compound 3: a limit, no number; the forecaster's own chance of this, stated with the estimate: 15%; middle value at least 7.6-fold (0.88 log units) away from the limit.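

In this assay compound 3 stands at a limit of the assay, not a number: the limit of > 1000000 nM in this assay, at which 1 of the 3 values shown sits. Hydrogen in place of methoxy on the aromatic carbon ortho to the group of 9 heavy atoms brings an at least 9.2-fold higher number from compound 2 to compound 3 (0.96 log units; beyond the scatter), while methoxy in place of hydrogen on an aromatic carbon brings an at least 5.8-fold higher number from compound 1 to compound 3 (0.76 log units; beyond the scatter). Losing one methoxy and gaining one thus both lead to a weaker inhibitor of growth, so this change has no single direction here. The compounds shown leave open how far the number of compound 3 lies past its limit, and what an amine or a carboxylic acid at this position would give.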